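The source may report more compounds than this note shows. Statements on the series, on what has been measured and on what is new or still open speak of the compounds shown alone.

Working notes on the series. The read-out throughout is a functional assay on HCT-15 cells (Homo sapiens) for cytotoxicity, read by sulforhodamine B assay, with a stated time of 48 h, tested at 50 uM; on this read-out higher numbers stand for more inhibition at the one concentration tested (going by the name of the read-out) and lower numbers for less inhibition. Compound 1, `Cc1ccc(Nc2nccc(-c3ccnc4ccccc34)n2)cc1`, gives 100% in this assay. Compound 2, `FC(F)(F)c1ccc(Nc2nccc(-c3cnc4ccccc4c3)n2)cc1`, gives 24% in this assay. Compound 3, `Nc1nccc(-c2cnc3ccccc3c2)n1`, shares its core with compound 2 but carries no group on the amino nitrogen; for compound 3 in this assay only "not active" (no number reported) is recorded, so compound 3 stands without a number, reported as not active. Compound 4, `Cc1ccc(Nc2nccc(-c3cnc4ccccc4c3)n2)cc1`, is the next member, still to be measured in this assay.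

The change from compound 3 to compound 4 is 4-methylphenyl in place of hydrogen on a nitrogen on an aromatic ring. Among the measured compounds shown here, no measured pair here shows this exact step, so its size can only be judged from what the two measured neighbours show: compound 2, with a substituted phenyl on the same nitrogen of the same core, gives 24%, and compound 1, with the same 4-methylphenyl on a different core, gives 100%. From a starting point reported as not active, a step upward in this assay well beyond the scatter is expected, though its size is uncertain because compound 2 sits at 24%. Compound 4 is expected to reach about 50% in this assay, estimated between 15% and 95%.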

Compound 4, a percentage reported as inhibition, at one concentration (the size of the read-out at that concentration, not a potency): 30.3%
Compound 4: middle estimate off by 19.7 percentage points, on the high side, and the stated range covers the measured number.
By their numbers in this assay, from the lowest: compounds 2 and 4 (each within the scatter of the next); then compound 1.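

In this assay, 4-methylphenyl in place of hydrogen on the nitrogen turns a compound reported as not active into one with a number, although no size can be read for this step since compound 3 has no value. Methyl in place of trifluoromethyl on an aromatic carbon gives a number 6.3 percentage points higher from compound 2 to compound 4 (within the scatter) and so does not separate the two groups at this position of the phenyl ring. With the same 4-methylphenyl on the nitrogen, compound 1 gives 100% on its own core and compound 4 gives 30.3% on the shared core, so this group alone does not set the number. Nothing on hand bears on the reason for these values.

Going by these compounds, it remains open whether an amine, a carboxylic acid or a longer chain in place of methyl on the phenyl ring would move the read-out beyond the scatter on the shared core. On these data alone, it is also open whether trifluoromethyl in place of methyl would leave the value of compound 1 unchanged on its own core.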